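The compounds below may be only part of what the source reports. "The series", "measured", "known", "first", "only" and "open" are said of these compounds alone.

Measured compounds:
compound 1, `COc1cccc(-c2cc(C(=O)Nc3ccc(Oc4ccnc5cc(OCCCN6CCCCC6)c(OC)cc45)c(F)c3)c3cc(F)ccc3n2)c1`, 2500 nM
compound 2, `COc1cc2c(Oc3ccc(NC(=O)c4cc(-c5ccc(C)cc5)nc5ccc(F)cc45)cc3F)ccnc2cc1OCCCN1CCCCC1`, 500 nM
compound 3, `COc1cccc(-c2cc(C(=O)Nc3ccc(Oc4ccnc5cc(OCCCN6CCC(C)CC6)c(OC)cc45)c(F)c3)c3cc(F)ccc3n2)c1`, 1210 nM

All three were run in a functional assay on HT-29 cells (Homo sapiens) for cytotoxicity, read by MTT assay, with a stated time of 72 h; a higher number here means a weaker inhibitor, a lower number a stronger inhibitor. Compound 1 gives 2500 nM in this assay, compound 2 gives 500 nM, and compound 3 gives 1210 nM. The two cores differ in one place, (methyl in place of hydrogen on a saturated ring carbon), and this change gives a 2.1-fold lower number from compound 1 to compound 3 (0.32 log units; beyond the scatter).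

Compound 4, `COc1cc2c(Oc3ccc(NC(=O)c4cc(-c5ccc(C)cc5)nc5ccc(F)cc45)cc3F)ccnc2cc1OCCCN1CCC(C)CC1`, is not yet measured. It differs from compound 3 by 4-methylphenyl in place of 3-methoxyphenyl on an aromatic carbon. The same change, at the same place, links the two measured compounds: 4-methylphenyl in place of 3-methoxyphenyl on an aromatic carbon, which gave a 5.0-fold lower number from compound 1 to compound 2 (0.70 log units; beyond the scatter).

Nothing beyond these three compounds shows how the two changes combine. Resting on the single measured step of a 5.0-fold lower number from compound 1 to compound 2 (0.70 log units; beyond the scatter), and applied to compound 3 with 1210 nM, the step from compound 3 to compound 4 is expected to be of about the same size, a 4.3-fold lower number from compound 3 to compound 4 (0.64 log units; beyond the scatter). Compound 4 is therefore estimated at 280 nM in this assay, with a range of 120 nM to 700 nM.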

Compound 4, half-maximal inhibitory concentration: 420 nM
The estimate for compound 4 lay 1.5-fold (0.18 log units) below the measured number; the measured number falls inside the stated range.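

In this assay, 4-methylphenyl in place of 3-methoxyphenyl gives a 2.9-fold lower number from compound 3 to compound 4 (0.46 log units; beyond the scatter) on the core that carries the extra methyl, and the step carries over from the first core with no difference that can be resolved: the same change on two cores in this assay, a 5.0-fold lower number (0.70 log units; beyond the scatter) from compound 1 to compound 2 and a 2.9-fold lower number (0.46 log units; beyond the scatter) from compound 3 to compound 4, 1.7-fold (0.24 log units) apart, within the scatter of two such steps

Methyl in place of hydrogen on a saturated ring carbon gives a 1.2-fold lower number from compound 2 to compound 4 (0.08 log units; within the scatter) on the 4-methylphenyl core, and the two readings of this change cannot be told apart either: the same change on two cores in this assay, a 2.1-fold lower number (0.32 log units; beyond the scatter) from compound 1 to compound 3 and a 1.2-fold lower number (0.08 log units; within the scatter) from compound 2 to compound 4, 1.7-fold (0.24 log units) apart, within the scatter of two such steps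

These notes rest on one pair of cores per change in one cell assay, so the two changes behave as roughly independent across these four compounds only; this does not show that either step would hold on a core altered elsewhere, nor that the paired steps are truly equal.

Still open, as far as these compounds go, is how other aryl groups next to the ring nitrogen, such as 4-chlorophenyl or unsubstituted phenyl, would compare with 4-methylphenyl. Also open, from the compounds shown here alone, is whether a hydroxyl or an ethyl in place of the methyl on the saturated ring would follow the same course.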